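The source may hold more compounds than are shown below. What is called first, only, known or untested is meant among the compounds shown, and "the series" means these compounds.

Working notes on the series.

Of the compounds shown here, three have been measured in a functional assay on CHO-K1 cells for antagonist activity at transient receptor potential cation channel subfamily V member 1 (Homo sapiens), read by FLIPR; on this read-out lower numbers stand for stronger inhibition and higher numbers for weaker inhibition. Compound 1 `CC(C(=O)NCc1ccc(C(F)(F)F)nc1Nc1ccccc1)c1ccc(NS(C)(=O)=O)c(F)c1` gives 59.6 nM, compound 2 `Cc1ccc(Nc2nc(C(F)(F)F)ccc2CNC(=O)C(C)c2ccc(NS(C)(=O)=O)c(F)c2)cc1C` gives 39.3 nM, and compound 3 `CC(C(=O)NCc1ccc(C(F)(F)F)nc1NCc1ccccc1)c1ccc(NS(C)(=O)=O)c(F)c1` gives 15.8 nM. Compound 2 thus stands second highest of the three numbers, with the step of a 1.5-fold lower number from compound 1 to compound 2 (0.18 log units; within the scatter) within the scatter and the step of a 2.5-fold lower number from compound 2 to compound 3 (0.40 log units; beyond the scatter) beyond it; the parallel step a 3.8-fold lower number from compound 1 to compound 3 (0.58 log units; beyond the scatter) points the same way.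

Compound 4 `CC(C(=O)NCc1ccc(C(F)(F)F)nc1N1CCCC1)c1ccc(NS(C)(=O)=O)c(F)c1` is not yet measured. It differs from compound 2 by pyrrolidin-1-yl in place of (3,4-dimethylphenyl)amino on an aromatic carbon. The steps from compound 2 that exist all change this same position, yet each keeps an aromatic ring on the nitrogen and its hydrogen-bond donor; none covers a non-aromatic ring entering in place of the whole (3,4-dimethylphenyl)amino group. The measured steps at this position were small to modest in either direction, so a modest step in this assay is expected, more likely toward a higher number, with wide uncertainty. The expected step is a 2.0-fold higher number from compound 2 to compound 4 (0.31 log units; beyond the scatter). Compound 4 is therefore estimated at about 80 nM, between 25 nM and 300 nM.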

Compound 4, inhibition constant: 0.6 nM
Compound 4: the middle estimate sits 130-fold (2.12 log units) above what was measured; measured number outside the range, below it.
By their numbers in this assay, from the lowest: compound 4; then compound 3; then compounds 2 and 1 (each within the scatter of the next).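

In this assay the aromatic carbon next to the ring nitrogen proves far more sensitive than the changes among anilino, (3,4-dimethylphenyl)amino and benzylamino suggested, with pyrrolidin-1-yl giving a large step from each of them (a 66-fold lower number from compound 2 to compound 4 (1.82 log units; beyond the scatter)), (a 26-fold lower number from compound 3 to compound 4 (1.42 log units; beyond the scatter)) and (a 99-fold lower number from compound 1 to compound 4 (2.00 log units; beyond the scatter)). The entering group has no aromatic ring and no hydrogen-bond donor, which shows that neither is needed at this position for a low number on this read-out. Which of these differences accounts for the gain cannot be told, as nothing at hand bears on it.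

Open, on these data alone, is whether cyclopentylamino, with a non-aromatic ring and the hydrogen-bond donor kept, would match pyrrolidin-1-yl. Also open, as far as these compounds go, is how far piperidin-1-yl, morpholin-4-yl or the open-chain diethylamino group would hold the gain.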